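Removing One Chloro Group From the Core of Compound 1

This account rests on a few compounds, and the source may have more. Where it says the series, first, only, none or still open, it means among the compounds named here.

Compound 1 `ClCc1cccc(Cn2cnc3nc(Cl)nc(Cl)c32)c1` has no result in a functional assay on HT-29 cells (Homo sapiens) for cytotoxicity, read by sulforhodamine B assay, with a stated time of 48 h; a higher number here means a weaker inhibitor of growth, a lower number a stronger inhibitor of growth; its entry reads "not determined" (no result reported), so it stands on no number at all. Its two companions both sit at an assay limit. Compound 2 `ClCc1ccc(Cn2cnc3c(Cl)nc(Cl)nc32)cc1` gives only a limit, > 100000 nM, not a number. Compound 3 `ClCc1ccccc1Cn1cnc2c(Cl)ncnc21` likewise gives only a limit, > 100000 nM. Both therefore rest at the limit of > 100000 nM in this assay, at which 2 of the 3 values shown sit, and nothing measured separates them. Compound 4 `ClCc1cccc(Cn2cnc3ncnc(Cl)c32)c1` differs from compound 1 in one place: hydrogen in place of chloro on an aromatic carbon. Among the measured compounds shown here, no step between measured compounds is available, so for this change in this assay no direction beyond the scatter is expected; the likeliest outcome, given that compound 2 and compound 3 rest at the limit of > 100000 nM in this assay, at which 2 of the 3 values shown sit, is another limit. Compound 4 is therefore expected to give about 150000 nM, within 30000 nM to 1000000 nM.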

Compound 4, concentration for total growth inhibition: > 100000 nM
Compound 4: only a limit was reported; the forecaster's own chance of this, stated with the estimate: 85%; the middle value is on the limit's open side.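

In this assay compound 4 gives > 100000 nM, which is a limit and not a number. Compound 1 has no result, so no step can be read between compound 1 and compound 4. The compounds shown leave open whether this chloro group has any bearing on growth inhibition.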